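This account rests on a few compounds, and the source may have more. Where it says the series, first, only, none or still open, it means among the compounds named here.

Working notes on the series. Among the measured compounds shown here, compound 1 `CN1CCN(CCCS(=O)(=O)c2ccc3nc(NC(=O)NC(=O)c4cc(-n5cccc5)ccc4Cl)sc3c2)CC1` is one of two compounds measured so far in an assay on HEK293 cells for displacement of a labelled ligand from growth hormone secretagogue receptor type 1 (Homo sapiens), with a stated time of 60 min; on this read-out lower numbers stand for stronger inhibition and higher numbers for weaker inhibition; compound 1 gives 0.15 nM. The other is compound 2 `CN1CCC(S(=O)(=O)c2ccc3nc(NC(=O)NC(=O)c4cc(N5CCCC5)c(C#N)cc4Cl)sc3c2)CC1`, which in this assay gives 0.4 nM. Compound 1 therefore holds the lowest of the two numbers, and compound 2 stands above it by a gap beyond the scatter. The two differ in several places at once, so no single step can be read from them.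

Compound 3 `Cc1ccn(-c2ccc(Cl)c(C(=O)NC(=O)Nc3nc4ccc(S(=O)(=O)CCCN5CCN(C)CC5)cc4s3)c2)n1`, not yet measured, differs from compound 1 in one place: 3-methyl-1H-pyrazol-1-yl in place of 1H-pyrrol-1-yl on an aromatic carbon. For the measured compounds named here, no measured pair shows this change, so nothing in the data sets its size. The expectation is a step that stays within the scatter, with no clear direction. The expected step of a 1.7-fold higher number from compound 1 to compound 3 (0.22 log units; within the scatter) reflects this. For compound 3 the estimate in this assay is 0.25 nM, with a range from 0.08 nM to 0.8 nM.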

Compound 3, half-maximal inhibitory concentration: 0.53 nM
Compound 3: the middle estimate sits 2.1-fold (0.33 log units) below what was measured; measured number inside the range.
By their numbers in this assay, from the lowest: compound 1; then compounds 2 and 3 (each within the scatter of the next).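

At this position, on an aromatic carbon meta to a large group and para to a chloro group, this assay now has its first step in a single place: 3-methyl-1H-pyrazol-1-yl in place of 1H-pyrrol-1-yl gives a 3.5-fold higher number from compound 1 to compound 3 (0.55 log units; beyond the scatter) in a modest change. The position therefore does register an exchange of one five-membered aromatic ring for another, with compound 3 at 0.53 nM still in the sub-nanomolar range. Nothing measured on hand speaks to what lies behind this step.

Going by these compounds, the change brings in a second ring nitrogen and a methyl group together, so their shares in the step stay open. Unsubstituted 1H-pyrazol-1-yl and 3-methyl-1H-pyrrol-1-yl at this position would separate the two.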